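Replacing the diethylcarbamoyl group on the shared core

The source may hold more compounds than are shown below. What is called first, only, known or untested is meant among the compounds shown, and "the series" means these compounds.

In a functional assay on the whole organism with Rattus norvegicus as the target (on this read-out lower numbers stand for an effect already at smaller amounts and higher numbers for an effect only at larger amounts of compound), compound 1 (`CCCn1c(=N)sc2cc(OC(F)(F)F)ccc21`) gives 4.5 mg/kg and compound 2 (`C#CCn1c(=N)sc2cc(OC(F)(F)F)ccc21`) gives 4 mg/kg while compound 3 (`CCN(CC)C(=O)Cn1c(=N)sc2cc(OC(F)(F)F)ccc21`) gives 9 mg/kg on the shared core. Compound 3 stays within the scatter of compound 1 (a 2.0-fold higher number from compound 1 to compound 3 (0.30 log units; within the scatter)) and is set apart only from compound 2 (a 2.3-fold higher number from compound 2 to compound 3 (0.35 log units; beyond the scatter)).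

Compound 4 (`C[S+]([O-])Cn1c(=N)sc2cc(OC(F)(F)F)ccc21`) has not yet been measured. It differs from compound 3 by one exchange (a group of 3 heavy atoms (1 carbon, 1 oxygen, 1 sulfur; no ring) in place of a group of 7 heavy atoms (5 carbon, 1 nitrogen, 1 oxygen; no ring), on a saturated chain carbon bound to an aromatic nitrogen) and keeps everything else. Among the measured compounds shown here, the steps that bear on it are the other exchanges at this same place. One stays within the scatter (a 1.1-fold lower number from compound 1 to compound 2 (0.05 log units; within the scatter)), and the largest of them, the step from compound 2 to compound 3 given above, is only modest. For the measured compounds named here, no measured compound carries the entering group, so these steps offer no direct precedent for it. They do show that three quite different groups at this place stay close together in this assay. A small move toward the values of compound 1 and compound 2 is therefore expected, with nothing firmly expected beyond the scatter. The estimated step is a 1.3-fold lower number from compound 3 to compound 4 (0.11 log units; within the scatter) in this case. For compound 4 the expected value is 7 mg/kg (estimated range 3 mg/kg to 15 mg/kg).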

Compound 4, dose for half-maximal effect: 2.3 mg/kg
Compound 4: middle estimate off by 3.0-fold (0.48 log units), on the high side, outside the stated range (below it).
By their numbers in this assay, from the lowest: compounds 4, 2, 1 and 3 (each within the scatter of the next, the first and the last beyond it).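

In this assay, the group of 3 heavy atoms (1 carbon, 1 oxygen, 1 sulfur) on a saturated chain carbon bound to an aromatic nitrogen gives the largest step seen so far at this place, a 3.9-fold lower number from compound 3 to compound 4 (0.59 log units; beyond the scatter), though this step is still only modest. The same group is not set apart from the other two groups it can be compared with, as shown by a 1.7-fold lower number from compound 2 to compound 4 (0.24 log units; within the scatter) and by a 2.0-fold lower number from compound 1 to compound 4 (0.29 log units; within the scatter), so a group containing sulfur and oxygen sits with the two small carbon groups, and only the diethylcarbamoyl group of compound 3 lies beyond the scatter of two of the other compounds, while compound 1 remains within the scatter of compound 3. No measurement beyond these doses is available to account for the step from the diethylcarbamoyl group.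

As far as these compounds go, whether the oxygen on the sulfur contributes to this result remains open, since neither a simple thioether nor a sulfone stands at this place for comparison. Also open, from the compounds shown here alone, is how an amine, a carboxylic acid or a longer carbon chain at this place would compare with these four compounds, and whether the diethylcarbamoyl result extends to smaller amides.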